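Triazole replacement of the ethynyl arm on the shared core

A few compounds are considered here, and "the series" means these few. Any claim that something is new, unique, unknown or untested is made for them only; others in the source may bear on it.

Measured compounds in a functional assay on HCC827 cells (Homo sapiens) for antiproliferative activity, read by sulforhodamine B assay, with a stated time of 72 h; a lower number here means a stronger inhibitor, a higher number a weaker inhibitor:
compound 1 `C#CCNCCN(C)CCNc1ccnc2cc(Cl)ccc12`, 105000 nM
compound 2 `CN(CCNCc1cn(Cc2ccccc2)nn1)CCNc1ccnc2cc(Cl)ccc12`, 16000 nM
compound 3 `CN(CCNCc1cn(Cc2ccc(Br)cc2)nn1)CCNc1ccnc2cc(Cl)ccc12`, 9300 nM

Compound 1 gives the highest number of the three in this assay; compound 2 and compound 3 both sit well below it. Within the data shown here, the only step between compounds differing in one place is a 1.7-fold lower number from compound 2 to compound 3 (0.24 log units; within the scatter), which says nothing about the arm itself. Compound 4 `CN(CCNCc1cn(CC(=O)O)nn1)CCNc1ccnc2cc(Cl)ccc12` is not yet measured; its difference from compound 1: 1-(carboxymethyl)-1H-1,2,3-triazol-4-yl in place of ethynyl on a saturated chain carbon bound to an amine nitrogen. Among the measured compounds shown here, no measured step covers a carboxymethyl on the triazole, so the expectation rests only on compound 1 standing far above compound 2 and compound 3. A lower number is expected, as a 2.3-fold lower number from compound 1 to compound 4 (0.37 log units; beyond the scatter), with compound 4 estimated at 45000 nM, range 12000 nM to 150000 nM.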

Compound 4, half-maximal inhibitory concentration: > 200000 nM
Compound 4: only a limit was reported (the forecaster's own chance of this, stated with the estimate: 15%); middle value at least 4.4-fold (0.64 log units) from the limit.
By their numbers in this assay, from the lowest: compounds 3 and 2 (each within the scatter of the next); then compound 1. At a limit, above all of these: compound 4.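

In this assay compound 4 gives only a limit, not a number: the limit of > 200000 nM in this assay, at which 1 of the 4 values shown sits. Carboxy on the saturated chain carbon bound to an aromatic nitrogen loses the lower numbers of the aryl-bearing triazoles, with an at least 12-fold higher number from compound 2 to compound 4 (1.09 log units; beyond the scatter) and an at least 21-fold higher number from compound 3 to compound 4 (1.33 log units; beyond the scatter). The triazole ring alone therefore brings no lower number than the ethynyl arm, with an at least 1.9-fold higher number from compound 1 to compound 4 (0.27 log units; that floor lies within the scatter), so how far compound 4 stands from compound 1 remains unresolved.

Open, going by these compounds, is whether the free carboxylic acid or the missing aryl ring decides this. A methyl ester, a primary amide or a simple butyl chain on the triazole would separate the two.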